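The source may hold more compounds than are shown below. What is called first, only, known or untested is meant among the compounds shown, and "the series" means these compounds.

Compound 3 `C#CCCCCOc1ccc2oc(=O)c(C(=O)OC)cc2c1` gives 123 nM in an assay on cells for inhibition of Amine oxidase [flavin-containing] B (Homo sapiens), read by Amplex Red, with stated times of 30 min and 45 min (on this read-out higher numbers stand for weaker inhibition and lower numbers for stronger inhibition), the lowest of the two numbers shown. Among the measured compounds shown here, its nearest neighbour is compound 1 `C#CCCCOc1ccc2oc(=O)c(C(=O)OC)cc2c1`, which gives 1440 nM in this assay, and the step of a 12-fold lower number from compound 1 to compound 3 (1.07 log units; beyond the scatter) is the only measured step in the set. Compound 2 `C#CCCCOc1ccc2cc(C(=O)Nc3ccc(F)cc3)c(=O)oc2c1` reaches only a limit of this assay, > 10000 nM, which is the limit of > 10000 nM in this assay, at which 1 of the 3 values shown sits. Compound 4 `C#CCCCCOc1ccc2oc(=O)c(C(=O)c3ccc(OC)cc3)cc2c1` differs from compound 3 by 4-methoxyphenyl in place of methoxy on a carbonyl carbon. No measured step matches this change: the one step shown alters the chain that carries the terminal alkyne and leaves the carbonyl carbon untouched, so it gives no guide to the size or direction here. Compound 1 and compound 2 differ from each other on the carbonyl carbon, and their two values show that a change there can carry the number out of the measurable range. The step from compound 3 to compound 4 is therefore expected to be a 2.8-fold higher number from compound 3 to compound 4 (0.45 log units; beyond the scatter), leaning toward a higher number with wide uncertainty. Compound 4 is estimated at 350 nM, between 60 nM and 3000 nM.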

Compound 4, half-maximal inhibitory concentration: > 10000 nM
Compound 4 ended at the assay's limit; the forecaster's own chance of this, stated with the estimate: 12%; middle value at least 28-fold (1.45 log units) from the limit.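

In this assay, from the compounds shown here alone, 4-methoxyphenyl in place of methoxy on a carbonyl carbon gives an at least 81-fold higher number from compound 3 to compound 4 (1.91 log units; beyond the scatter), and compound 4 stands at a limit of the assay, so the full size of this step stays unknown. Earlier, only compound 1 and compound 2 spoke for this carbonyl carbon, and the result now shows that the longer chain of compound 3 does not keep the number within the measurable range once 4-methoxyphenyl sits there. Both compounds at the limit carry a six-membered aromatic ring on the carbonyl side in place of methoxy: the limit of > 10000 nM in this assay, at which 2 of the 4 values shown sit.

The compounds shown leave open whether ethoxy, a carboxylic acid or an unsubstituted amide on this carbonyl carbon would keep the number low. They also leave open whether a chain longer than that of compound 3 would lower it further.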